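The source may report more compounds than this note shows. Statements on the series, on what has been measured and on what is new or still open speak of the compounds shown alone.

Measured so far in a functional assay on HEK293 cells with D(4) dopamine receptor (Homo sapiens) as the target, read by FLIPR; on this read-out lower numbers stand for an effect already at smaller amounts and higher numbers for an effect only at larger amounts of compound:
- compound 1, `O/N=C(\CCN1CCN(c2ccccn2)CC1)c1ccccc1`: 4.4 nM
- compound 2, `N#Cc1cccnc1N1CCN(CC/C(=N\O)c2ccccc2)CC1`: 18 nM
- compound 3, `N#Cc1cccnc1N1CCN(CC/C(=N/O)c2ccccc2)CC1`: 20 nM

Among these three numbers compound 2 holds the second highest; its nearest neighbour is compound 3, and the two lie within the scatter of each other, while compound 1 is furthest away, with a 4.1-fold higher number from compound 1 to compound 2 (0.61 log units; beyond the scatter) separating them. Compound 3 differs from compound 2 only in how the double bond is drawn, and that pair gives a 1.1-fold higher number from compound 2 to compound 3 (0.05 log units; within the scatter), which is what the fact that compounds 2 and 3 differ only in the configuration as drawn would lead one to expect.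

Compound 4, `O/N=C(\CCN1CCN(c2ncccn2)CC1)c1ccccc1`, has not been measured. It arises from compound 2 through (pyrimidin-2-yl in place of 3-cyanopyridin-2-yl on an amine nitrogen in a ring). Going by the values given here, only one measured step touches this change: a 4.1-fold higher number from compound 1 to compound 2 (0.61 log units; beyond the scatter), which added the cyano to the ring on that amine nitrogen and moved the number upward by a modest amount. Among the compounds with values here, compound 4 removes that cyano again but also swaps the ring itself for a pyrimidin-2-yl, a change no measured pair covers. The expectation is therefore a modest step back downward, a 3.0-fold lower number from compound 2 to compound 4 (0.48 log units; beyond the scatter), with added uncertainty from the ring swap. Compound 4 is estimated at 6 nM in this assay, with a likely range from 2 nM to 25 nM.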

Compound 4, half-maximal effective concentration: 39.2 nM
For compound 4 the middle estimate is 6.5-fold (0.82 log units) below the measured one; the measured number lies above the stated range.
By their numbers in this assay, from the lowest: compound 1; then compounds 2, 3 and 4 (each within the scatter of the next, the first and the last beyond it).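

In this assay, the ring on the amine nitrogen turns out to matter even when no cyano group is involved: pyrimidin-2-yl in place of pyridin-2-yl, a swap that puts a second hetero atom into the aromatic ring, gives an 8.9-fold higher number from compound 1 to compound 4 (0.95 log units; beyond the scatter). Going by these compounds alone, until now, the only measured change at this position was the addition of the cyano group, and that step, a 4.1-fold higher number from compound 1 to compound 2 (0.61 log units; beyond the scatter), could not show whether the ring itself counts. The direct comparison, a 2.2-fold higher number from compound 2 to compound 4 (0.34 log units; beyond the scatter), adds that 3-cyanopyridin-2-yl and pyrimidin-2-yl are not interchangeable here, and both replacements of the pyridin-2-yl of compound 1 move the number upward, so among these compounds the plain pyridin-2-yl gives the lowest number.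

Nothing measured here accounts for why the pyrimidin-2-yl ring shifts the number in this way. On these data alone, it also remains open how this position would respond to a plain phenyl ring, or to a methoxy group or a fluorine atom on the pyridin-2-yl ring, and whether a cyano group on the pyrimidin-2-yl ring would shift the number as it does on pyridin-2-yl.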